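A few compounds are considered here, and "the series" means these few. Any claim that something is new, unique, unknown or untested is made for them only; others in the source may bear on it.

Series values in a functional assay on NCI-H292 cells (Homo sapiens) for cytotoxicity, read by MTT assay, with a stated time of 72 h, tested at 2.5 ug/mL; a higher number here means more inhibition of growth at the concentration tested, a lower number less inhibition of growth:

- compound 1 `O=C1NC(=S)/C(=C/c2ccc(Cl)cc2)S1` gives 28.6%
- compound 2 `O=C1NC(=S)/C(=C/c2cc(Cl)cc(Cl)c2Cl)S1` gives 33%
- compound 3 `O=C1NC(=S)/C(=C/c2ccccc2Br)S1` gives 16.2%

Compound 1 stands within the scatter of compound 2 and beyond the scatter from compound 3, which gives the lower number. Compound 4 `O=C1NC(=S)/C(=C/c2ccc(Br)cc2)S1` differs from compound 1 by one swap, bromo in place of chloro on an aromatic carbon. Going by the values given here, no two measured compounds differ in one place only, so the size of such a swap has not been seen directly in this assay. Compound 3 also carries bromo, but the ring of compound 3 is substituted differently from that of compound 4, so it is only a weak guide. The anchor is therefore compound 1 at 28.6% in this series. The expected size of the step of a number 0.6 percentage points lower from compound 1 to compound 4 (within the scatter) is none beyond the scatter, with no firm direction. Compound 4 is estimated at 28% with an expected range from 15% to 41% in this assay.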

Compound 4, percent growth inhibition at one concentration: 1.19%
The estimate for compound 4 lay 26.8 percentage points above the measured number; measured number outside the range, below it.
By their numbers in this assay, from the lowest: compound 4; then compound 3; then compounds 1 and 2 (each within the scatter of the next).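

Bromo in place of chloro on an aromatic carbon, para to a group of 8 heavy atoms, is the first single change that can be read in this assay, and it comes to a number 27.4 percentage points lower from compound 1 to compound 4 (beyond the scatter). This place in the series therefore does not treat the two halogens alike, even though one heavy atom replaces one heavy atom and no hydrogen-bond donor, acceptor or net charge enters or leaves. No measurement on these compounds accounts for the size of this step.

One pair cannot show whether the step is particular to this place or would recur with bromo elsewhere on the ring. Fluoro, methoxy or an amine at the same place would show whether chloro or bromo is the unusual member.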